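This account rests on a few compounds, and the source may have more. Where it says the series, first, only, none or still open, it means among the compounds named here.

Measured so far in a physicochemical assay for solubility, read by spectrophotometry, with a stated time of 24 h, at pH 7.4; on this read-out lower numbers stand for lower solubility and higher numbers for higher solubility:
- compound 1 `CN(C)c1ccc(C(=O)N/N=C/c2ccc(C(=O)NO)cc2)cc1`: 15000 nM
- compound 2 `COC(=O)c1ccc(/C=N/N(C)C(=O)c2ccc(N(C)C)cc2)cc1`: 1400 nM

Compound 2, at 1400 nM, holds the lower of the two numbers. Compound 1, at 15000 nM, lies above it by a gap beyond the scatter.

The next compound to be read is compound 3 `CN(/N=C/c1ccc(C(=O)NO)cc1)C(=O)c1ccc(N(C)C)cc1`. Its difference from compound 2 is hydroxyamino in place of methoxy on a carbonyl carbon, with hydroxyamino in place of methoxy on a carbonyl carbon. The same difference, cut one bond further out, reads methoxycarbonyl to hydroxycarbamoyl.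

Within the data shown here, no measured pair shows this change on its own, so the size of the step is poorly constrained. An upward step in this assay, beyond the scatter, is expected. Among the measured compounds shown here, the only pointer is compound 1, which also bears hydroxycarbamoyl and stands at 15000 nM. Compound 1 and compound 3 are not otherwise the same, so a wide range is kept. The estimate amounts to a 5.0-fold higher number from compound 2 to compound 3 (0.70 log units; beyond the scatter). For compound 3 the expected value is 7000 nM, with an estimated range of 2500 nM to 20000 nM.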

Compound 3, solubility: > 64000 nM
Compound 3 ended at the assay's limit; the forecaster's own chance of this, stated with the estimate: 10%; middle value at least 9.1-fold (0.96 log units) away from the limit.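

In this assay, hydroxyamino in place of methoxy on a carbonyl carbon now has a direct reading in a one-place pair, which gives an at least 45-fold higher number from compound 2 to compound 3 (1.66 log units; beyond the scatter). Methyl in place of hydrogen on an amide-type nitrogen also has its first reading, with hydroxycarbamoyl present in both compounds, which gives an at least 4.2-fold higher number from compound 1 to compound 3 (0.63 log units; beyond the scatter); both one-place changes leading to compound 3 therefore move upward, and each step is a lower bound, not a full size. Compound 3 gives a limit of the assay and not a number: the limit of > 64000 nM in this assay, at which 1 of the 3 values shown sits.

On these data alone, how far compound 3 lies past that limit remains open, so neither step has an upper bound, and the methyl change on the amide-type nitrogen is read only with hydroxycarbamoyl present, not with methoxycarbonyl. Also open, as far as these compounds go, is where a carboxylic acid or a primary amide in place of methoxycarbonyl would fall in this assay, and whether an ethyl on the amide-type nitrogen would read like methyl.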